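Replacing the amino group on the amide nitrogen

The source may report more compounds than this note shows. Statements on the series, on what has been measured and on what is new or still open speak of the compounds shown alone.

In a functional assay on HeLa cells (Homo sapiens) for cytotoxicity, read by MTT assay, with a stated time of 72 h (a higher number here means a weaker inhibitor, a lower number a stronger inhibitor), compound 1 `CCN(CC)c1ccc2cc(C(=O)NC(C)C)c(=O)oc2c1` gives 73000 nM. Compound 2 `CCN(CC)c1ccc2cc(C(=O)NC3CC3)c(=O)oc2c1` returns only a limit, > 100000 nM, being (the limit of > 100000 nM in this assay, at which 1 of the 3 values shown sits). Compound 3 `CCN(CC)c1ccc2cc(C(=O)NN)c(=O)oc2c1` gives 5480 nM, the lowest of the two numbers shown; the nearest is compound 1, with a 13-fold lower number from compound 1 to compound 3 (1.12 log units; beyond the scatter). In the same direction there is an at least 18-fold lower number from compound 2 to compound 3 (1.26 log units; beyond the scatter). Compound 4 `CCN(CC)c1ccc2cc(C(=O)N/N=C(/C)c3cccs3)c(=O)oc2c1` carries a group of 8 heavy atoms (6 carbon, 1 nitrogen, 1 sulfur; one five-membered aromatic ring with 1 hetero atom) in place of one nitrogen atom, on an amide-type nitrogen. Both measured steps onto the amino group lowered the number by large amounts, but neither step involves a substituent of this size on that nitrogen, so the expected step of a 1.8-fold lower number from compound 3 to compound 4 (0.26 log units; within the scatter) is modest and uncertain. Compound 4 is therefore estimated at 3000 nM, within a range from 500 nM to 20000 nM.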

Compound 4, half-maximal inhibitory concentration: > 100000 nM
Compound 4 was reported as a limit; the forecaster's own chance of this, stated with the estimate: 10%; at least 33-fold (1.52 log units) between middle value and limit.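

Replacing the amino group on the amide-type nitrogen with the group of 8 heavy atoms removes the advantage seen in this assay, with an at least 18-fold higher number from compound 3 to compound 4 (1.26 log units; beyond the scatter). Measured against the isopropyl group, the same change gives an at least 1.3-fold higher number from compound 1 to compound 4 (0.13 log units; that floor lies within the scatter), so no order can be drawn there. The step from compound 2 to compound 4 cannot be read, as both values are limits: the limit of > 100000 nM in this assay, at which 2 of the 4 values shown sit.

Going by these compounds, whether a methylamino or acetylamino group on that nitrogen would keep the lower number of compound 3 stays open. Also open, on these data alone, is whether the double bond or the five-membered aromatic ring accompanies the loss.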